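Swapping amino for chloro at a cytotoxicity limit

A few compounds are considered here, and "the series" means these few. Any claim that something is new, unique, unknown or untested is made for them only; others in the source may bear on it.

- Compound 1 (`O[C@H]1C[C@@H](Cn2cnc3c(Cl)ncnc32)c2ccccc21`) gives > 200000 nM as a limit, not a number
- Compound 2 (`Nc1nc2c(nc(N)n2COCCO)c(=O)[nH]1`) gives > 200000 nM as a limit, not a number

Both readings come from an ADME assay on L1210/0 cells (Mus musculus) for cytotoxicity, with a stated time of 48 h (a higher number here means a weaker inhibitor, a lower number a stronger inhibitor), and neither is an exact number. Compound 2 therefore has a place only at > 200000 nM on this scale, and that place is a limit. For the measured compounds named here, the whole measured picture is the limit of > 200000 nM in this assay, at which 2 of the 2 values shown sit, and no step between measured compounds is available as a guide.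

Compound 3 (`Nc1nc2c(nc(Cl)n2COCCO)c(=O)[nH]1`) differs from compound 2 in one place (chloro in place of amino on an aromatic carbon). The chloro group of compound 3 sits between two ring nitrogen atoms, next to the ring atom that bears a (2-hydroxyethoxy)methyl group.

In this assay the expectation is for little or no change beyond the scatter, with any small move going towards stronger inhibition. This expectation rests on compound 2 giving > 200000 nM as a limit. Written as a step, the expected change is an at least 1.3-fold lower number from compound 2 to compound 3 (0.12 log units; that floor lies within the scatter) as an estimate only. The estimate for compound 3 is 150000 nM with an expected range from 50000 nM to 300000 nM in this measurement.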

Compound 3, half-maximal inhibitory concentration: > 200000 nM
Compound 3: a limit, no number; the forecaster's own chance of this, stated with the estimate: 70%; middle value at least 1.3-fold (0.12 log units) from the limit.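

The step from amino to chloro between compound 2 and compound 3 cannot be read, because neither compound gives an exact number in this assay: the limit of > 200000 nM in this assay, at which 3 of the 3 values shown sit. The compounds shown leave open what exact value either compound would give, and so whether chloro in place of amino changes the reading at all.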